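A few compounds are considered here, and "the series" means these few. Any claim that something is new, unique, unknown or untested is made for them only; others in the source may bear on it.

Compound 1, `CC1(C)CC2CC(C)(CN2C(=O)c2sc(-c3ccc(S(C)(=O)=O)c([N+](=O)[O-])c3)nc2C(F)(F)F)C1`, gives in a functional assay on HepG2 cells (Homo sapiens) for cytotoxicity, read by luminescence, with a stated time of 72 h (a lower number here means that less compound is needed, a higher number that more compound is needed for the effect), only a limit, > 27000 nM.
Compound 2, `CC1Cc2ccccc2N1C(=O)c1sc(-c2ccc(S(C)(=O)=O)c([N+](=O)[O-])c2)nc1C(F)(F)F`, gives in this assay likewise only a limit, > 27000 nM.

Among the measured compounds shown here, compound 2 therefore stands at the limit of this assay, and the one further value shown is a limit as well, so the step that the two limits leave unreadable from compound 1 to compound 2 cannot be read from the two numbers. Both values sit together at the limit (the limit of > 27000 nM in this assay, at which 2 of the 2 values shown sit). The change to compound 3, `CN(Cc1ccccc1)C(=O)c1sc(-c2ccc(S(C)(=O)=O)c([N+](=O)[O-])c2)nc1C(F)(F)F`, is benzyl(methyl)amino in place of 2-methyl-2,3-dihydro-1H-indol-1-yl on a carbonyl carbon. The only measured step bears on this change, but its size is not readable, so no direction can be taken from it; nothing in the numbers shown suggests a move away from the limit. Compound 3 is thus expected to remain at the limit, estimated at 40000 nM with a range from 15000 nM to 200000 nM. The expected step that the limit leaves unreadable from compound 2 to compound 3 is, by this estimate, one that the limit would again leave unreadable.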

Compound 3, half-maximal effective concentration: > 27000 nM
Compound 3: no number, only a limit; the forecaster's own chance of this, stated with the estimate: 85%; the middle value lies beyond the limit too.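

Compound 1, compound 2 and compound 3 all sit at a limit and give no number, so no step among them can be read: the limit of > 27000 nM in this assay, at which 3 of the 3 values shown sit.

The compounds shown leave open where the true values of all three lie, and whether any group on the carbonyl carbon would give a readable value in this assay.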